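The source may report more compounds than this note shows. Statements on the series, on what has been measured and on what is new or still open speak of the compounds shown alone.

Compound 1 `COc1cc(/C=C/C2CC(=O)C=CO2)cc(OC)c1OC`: 85.4 uM
Compound 2 `COc1ccc(/C=C/C2CC=CC(=O)N2)cc1OC`: > 964 uM

In a functional assay on OVCAR-3 cells (Homo sapiens) for inhibition, read by sulforhodamine B assay, with a stated time of 48 h (on this read-out lower numbers stand for stronger inhibition of growth and higher numbers for weaker inhibition of growth), compound 1 gives 85.4 uM. For compound 2 the value > 964 uM is only a limit of this assay, not a measured number (the limit of > 964 uM in this assay, at which 1 of the 2 values shown sits). Compound 3 `COc1cc(/C=C/C2CC=CC(=O)N2)cc(OC)c1OC` has not yet been measured. It differs from compound 2 by methoxy in place of hydrogen on an aromatic carbon. Going by the values given here, no measured step between compounds that differ in one place is available, so the size of this change cannot be read from the data. A modest gain beyond the scatter is expected, giving a step of an at least 1.9-fold lower number from compound 2 to compound 3 (0.28 log units; that floor lies within the scatter). Compound 3 is estimated at 500 uM, within 100 uM to 2000 uM.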

Compound 3, concentration for growth inhibition (reported as GI): > 864 uM
Compound 3 gave a limit, no number (the forecaster's own chance of this, stated with the estimate: 45%); at least 1.7-fold (0.23 log units) between middle value and limit.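

Compound 3 gives > 864 uM, which is a limit of this assay and not a number. With compound 2 also at a limit, the step for methoxy in place of hydrogen cannot be read, so this position shows no measurable effect of the change. Going by these compounds alone, exchanging the ring group holding two oxygens for the one holding a nitrogen and an oxygen gives an at least 10-fold higher number from compound 1 to compound 3 (1.00 log units; beyond the scatter), the first readable comparison here.

Going by these compounds, whether a hydroxyl group or a chlorine atom at this position would give a measurable number remains open. On these data alone, the size of any methoxy effect also remains unknown.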